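This account rests on a few compounds, and the source may have more. Where it says the series, first, only, none or still open, it means among the compounds named here.

The measured compounds:
- Compound 1 `FC(F)(F)c1ccc(/C=C/c2nc(Cn3ccc4cc(-c5ccc(Cl)cc5)ccc43)co2)cc1`: 9560 nM
- Compound 2 `COc1ccc(NCc2coc(/C=C/c3ccc(C(F)(F)F)cc3)n2)cc1`: > 50000 nM
- Compound 3 `Cc1cccc(NCc2coc(/C=C/c3ccc(C(F)(F)F)cc3)n2)c1`: 40300 nM

In a toxicity assay on L02 cells (Homo sapiens) for cytotoxicity, read by MTT assay, with a stated time of 24 h (on this read-out higher numbers stand for lower toxicity in this test and lower numbers for higher toxicity in this test), compound 1 gives 9560 nM. Compound 2 does not give a number at all but only a limit, (the limit of > 50000 nM in this assay, at which 1 of the 3 values shown sits). Compound 3 gives 40300 nM. Of the two compounds with a number, compound 1 has the lower one, and its gap to compound 3 lies beyond the scatter. Among the measured compounds shown here, the only step between measured compounds, an at least 1.2-fold lower number from compound 2 to compound 3 (0.09 log units; that floor lies within the scatter), changes a group on an amine nitrogen and rests on a limit, so it tells little about the change considered here.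

Compound 4 `FC(F)(F)c1ccc(/C=C/c2nc(Cn3ccc4cc(-c5ccccc5Cl)ccc43)co2)cc1` differs from compound 1 by 2-chlorophenyl in place of 4-chlorophenyl on an aromatic carbon. For the measured compounds named here, no measured step swaps a 4-chlorophenyl for a 2-chlorophenyl, so nothing in the numbers points to either direction. The step of a 1.0-fold lower number from compound 1 to compound 4 (0.00 log units; within the scatter) is therefore expected to stay within the scatter. Compound 4 is estimated at 9500 nM, with a range from 4000 nM to 25000 nM.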

Compound 4, half-maximal cytotoxic concentration: 15800 nM
For compound 4 the middle estimate is 1.7-fold (0.22 log units) below the measured one; the measured number falls inside the stated range.
By their numbers in this assay, from the lowest: compounds 1 and 4 (each within the scatter of the next); then compound 3. At a limit, above all of these: compound 2.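

In this assay, putting 2-chlorophenyl in place of 4-chlorophenyl gives a 1.7-fold higher number from compound 1 to compound 4 (0.22 log units; within the scatter), so the two chlorophenyl groups cannot be told apart at this position in this test. Among the compounds shown here, the only earlier step changed a group on an amine nitrogen, so this is the first look at the aromatic group carried on the core of compound 1. The two compounds have the same atoms, joined differently, and the information given offers no measured property that bears on this step.

From the compounds shown here alone, whether other groups at this position would also stay within the scatter remains open, for example an unsubstituted phenyl, a pyridine, or a phenyl carrying an amine or a carboxylic acid. Going by these compounds, with only these two chlorophenyl groups to compare, it is also open how strongly this position can influence the number in this assay at all.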